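Removing the Cyclohexylmethyl Ester Group from Compound 2

The compounds below may be only part of what the source reports. "The series", "measured", "known", "first", "only" and "open" are said of these compounds alone.

Among the measured compounds shown here, compound 2 `C/C=C1/[C@H](O[C@@H]2O[C@H](CO)[C@@H](O)[C@H](O)[C@H]2O)OC=C(C(=O)OC)[C@H]1CC(=O)OCCC1CCCCC1` is the only one of the three compounds with a numerical result in a functional assay on SK-BR-3 cells (Homo sapiens) for antiproliferative activity, read by MTT assay, with a stated time of 72 h (on this read-out lower numbers stand for stronger inhibition and higher numbers for weaker inhibition), where compound 2 gives 2000 nM. Compound 1 `C=C(C)CCOC(=O)C[C@@H]1C(C(=O)OC)=CO[C@@H](O[C@@H]2O[C@H](CO)[C@@H](O)[C@H](O)[C@H]2O)/C1=C/C` reaches only a limit of the assay in this assay, at > 15000 nM. Compound 3 `C/C=C1/[C@H](O[C@@H]2O[C@H](COC(C)=O)[C@@H](OC(C)=O)[C@H](OC(C)=O)[C@H]2OC(C)=O)OC=C(C(=O)OC)[C@H]1CC(=O)O` likewise stops at a limit in this assay, at > 15000 nM. For the measured compounds named here, the single measured step, an at least 7.5-fold lower number from compound 1 to compound 2 (0.87 log units; beyond the scatter), is the one comparison that touches the ester portion, and the cyclohexyl group there goes with the lower number; its true size is unknown because it rests on (the limit of > 15000 nM in this assay, at which 2 of the 3 values shown sit). Compound 4 `C/C=C1/[C@H](O[C@@H]2O[C@H](CO)[C@@H](O)[C@H](O)[C@H]2O)OC=C(C(=O)OC)[C@H]1CC(=O)OC` differs from compound 2 by hydrogen in place of cyclohexylmethyl on a saturated chain carbon bound to an oxygen next to a carbonyl group, so the cyclohexyl group that set compound 2 apart is gone altogether. Compound 4 is therefore expected to give a higher number in this assay, with an estimated step of a 6.0-fold higher number from compound 2 to compound 4 (0.78 log units; beyond the scatter), and may well end at the same limit as compounds 1 and 3. The estimated value for compound 4 in this assay is 12000 nM, within 4000 nM to 30000 nM.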

Compound 4, half-maximal inhibitory concentration: > 15000 nM
Compound 4 gave a limit, no number; the forecaster's own chance of this, stated with the estimate: 55%; middle value at least 1.2-fold (0.09 log units) from the limit.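

Replacing 2-cyclohexylethoxy with methoxy gives an at least 7.5-fold higher number from compound 2 to compound 4 (0.87 log units; beyond the scatter) in this assay. Among the compounds shown here, until now, the cyclohexyl group had been compared only with 1-methylethenyl on the ester chain; this second comparison shows that removing cyclohexylmethyl altogether, leaving hydrogen on that carbon, also loses the measurable number of compound 2, which remains the only compound here with one. The step from compound 1 to compound 4 cannot be read, and the step to compound 4 gives only a bound on the true size of the change: the limit of > 15000 nM in this assay, at which 3 of the 4 values shown sit.

The compounds shown leave open whether the lower number depends on the cyclohexane ring itself or would also appear with a longer straight alkyl chain or a phenyl ring at this place. They also leave open what an amide in place of this ester would give.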